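The source may hold more compounds than are shown below. What is called first, only, known or untested is meant among the compounds shown, and "the series" means these compounds.

Working notes on the series.

The shared core carries an anilino substituent and a prop-1-yn-1-yl chain whose saturated carbon bears an amine. Compound 1 `CN1CCN(CC#Cc2cc3ncnc(Nc4ccc(OCc5cccc(F)c5)c(Cl)c4)c3s2)CC1` has the 4-methylpiperazin-1-yl group there, and in an ADME assay on NIH3T3 cells (Mus musculus) for cytotoxicity (on this read-out higher numbers stand for lower toxicity in this test and lower numbers for higher toxicity in this test), compound 1 gives 4.8 uM. Compound 2 `CCOC(=O)CN(C)CC#Cc1cc2ncnc(Nc3ccc(OCc4cccc(F)c4)c(Cl)c3)c2s1` differs by one change, (((ethoxycarbonyl)methyl)(methyl)amino in place of 4-methylpiperazin-1-yl on a saturated chain carbon bound to a triple-bonded carbon), and in this assay compound 2 gives 52 uM. That change made a step of an 11-fold higher number from compound 1 to compound 2 (1.03 log units; beyond the scatter).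

Compound 3 `CN1CCN(CC#Cc2ccc3ncnc(Nc4ccc(OCc5cccc(F)c5)c(Cl)c4)c3c2)CC1` keeps the 4-methylpiperazin-1-yl group on another core; the difference between the two cores is not broken down here. In this assay compound 3 gives 7.2 uM, which sits within the scatter of compound 1, so no order between them is claimed.

Compound 4 `CCOC(=O)CN(C)CC#Cc1ccc2ncnc(Nc3ccc(OCc4cccc(F)c4)c(Cl)c3)c2c1` is compound 3 with the same change, (((ethoxycarbonyl)methyl)(methyl)amino in place of 4-methylpiperazin-1-yl on a saturated chain carbon bound to a triple-bonded carbon). The change sits at the same place as in the pair of compound 1 and compound 2, so it is the same change, and it has been seen once before in this set.

For the measured compounds named here, the only precedent is the step of an 11-fold higher number from compound 1 to compound 2 (1.03 log units; beyond the scatter). On that basis the expected step is a 7.6-fold higher number from compound 3 to compound 4 (0.88 log units; beyond the scatter), of a size comparable to the one seen before, since nothing in the set shows the two cores responding differently and compound 3 starts within the scatter of compound 1. Compound 4 is therefore estimated at 55 uM, with an expected range from 20 uM to 150 uM. The measured value will show whether the second core carries the change in the same way.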

Compound 4, half-maximal toxic concentration: > 50 uM
Compound 4 ended at the assay's limit (the forecaster's own chance of this, stated with the estimate: 15%); the middle value lies beyond the limit too.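

In this assay compound 4 gives > 50 uM, which is a limit of the assay and not a number. For the compounds shown here, replacing 4-methylpiperazin-1-yl with ((ethoxycarbonyl)methyl)(methyl)amino on the saturated chain carbon bound to a triple-bonded carbon therefore gives a step in the same direction on the second core, an at least 6.9-fold higher number from compound 3 to compound 4 (0.84 log units; beyond the scatter), so on both cores the change goes with lower toxicity in this test, though this rests on only two pairs. The result does not show that the change has the same size on the two cores, and it gives no true value for compound 4, so the comparison remains bounded on one side only: the same change on two cores in this assay, an 11-fold higher number (1.03 log units; beyond the scatter) from compound 1 to compound 2 and an at least 6.9-fold higher number (0.84 log units; beyond the scatter) from compound 3 to compound 4; the limit leaves it open whether they differ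

The compounds shown do not separate the loss of the 4-methylpiperazin-1-yl ring from the arrival of the ethoxycarbonyl group, and a dimethylamino or morpholin-4-yl group on the same saturated chain carbon would help to tell these apart. Also open, as far as these compounds go, are whether the ethyl ester itself matters, which a carboxylic acid or an amide in its place would address, and whether the step holds on any core other than these two.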